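The source may hold more compounds than are shown below. What is called first, only, known or untested is meant among the compounds shown, and "the series" means these compounds.

The measured compounds in a functional assay on J774 cells (Mus musculus) for cytotoxicity, read by resazurin assay, with a stated time of 72 h; a higher number here means a weaker inhibitor, a lower number a stronger inhibitor:

compound 1 `Cc1c(CO)cccc1NS(=O)(=O)c1ccc(-c2ccc(Br)cc2)cc1`, where compound 1 gives 750 nM.
compound 3 `O=S(=O)(Nc1cccc(CO)c1Cl)c1ccc(-c2ccc(Br)cc2)cc1`, where compound 3 gives 5000 nM.
compound 2 `Cc1ccc(CO)cc1NS(=O)(=O)c1ccc(-c2ccc(Br)cc2)cc1`, where compound 2 gives only a limit of the assay, > 5000 nM, and not a number.

Compound 1 and compound 3 share the same core and differ in one place: chloro in place of methyl on an aromatic carbon. In this assay that change gave a 6.7-fold higher number from compound 1 to compound 3 (0.82 log units; beyond the scatter), so compound 3 is the weaker inhibitor of the two. Compound 2 has the same atoms as compound 1, joined differently; the difference between the two cores is not broken down here. For compound 2 the assay reports (the limit of > 5000 nM in this assay, at which 1 of the 3 values shown sits), so only a limit is known for it.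

Compound 4 `O=S(=O)(Nc1cc(CO)ccc1Cl)c1ccc(-c2ccc(Br)cc2)cc1` has not yet been measured. It differs from compound 2 by chloro in place of methyl on an aromatic carbon. For the measured compounds named here, this is the same kind of change as the one from compound 1 to compound 3, but not the same: in compound 3 the chloro is ortho to a hydroxymethyl group (2 heavy atoms) and ortho to a large group, while in compound 4 it is ortho to a large group and para to a hydroxymethyl group (2 heavy atoms). The earlier step moved the number upward, and a step in the same direction is expected from compound 2 to compound 4, a step that the limit leaves unreadable from compound 2 to compound 4, which rests on compound 2 already sitting at the limit of > 5000 nM in this assay, at which 1 of the 3 values shown sits. Compound 4 is therefore estimated at 20000 nM, with a range expected from 5000 nM to 80000 nM, and the assay is expected to report only a limit again.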

Compound 4, half-maximal inhibitory concentration: 2000 nM
Compound 4: middle estimate off by 10-fold (1.00 log units), on the high side, outside the stated range (below it).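

Compound 2 gives > 5000 nM, which is a limit of the assay and not a number. Measured against that limit in this assay, chloro in place of methyl on an aromatic carbon gives an at least 2.5-fold lower number from compound 2 to compound 4 (0.39 log units; beyond the scatter), so in these two pairs the same change does not carry from one core to the other, and its direction is reversed: the same change on two cores in this assay, a 6.7-fold higher number (0.82 log units; beyond the scatter) from compound 1 to compound 3 and an at least 2.5-fold lower number (0.39 log units; beyond the scatter) from compound 2 to compound 4, at least 16-fold (1.22 log units) apart, beyond the scatter of two such steps. The two pairs show that the effect of this swap cannot simply be transferred between these cores, but they do not show why the direction differs, and they give only a minimum for the size of the step to compound 4, not its true size.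

The compounds shown leave open whether the reversal belongs to this chloro and methyl pair alone, or whether another small group in the same place, such as fluoro, methoxy or nitrile, would also move the number in opposite directions on the two cores. They also leave open how the series would respond if the hydroxymethyl group were replaced by an amine, a carboxylic acid or a longer chain.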